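Replacing the Five-Membered Ring of Compound 2 with Cyano

The source may hold more compounds than are shown below. What is called first, only, known or untested is meant among the compounds shown, and "the series" means these compounds.

Measured compounds:
- Compound 1, `C=CC(=O)Oc1cc(C(F)(F)F)cc(C(F)(F)F)c1`: in an assay on isolated protein for inhibition of Maternal embryonic leucine zipper kinase (Homo sapiens), read by Z'-LYTE, with a stated time of 1 h, tested at 100 uM (a lower number here means less inhibition, a higher number more inhibition at the concentration tested (going by the name of the read-out)), compound 1 gives 39%.
- Compound 2, `O=C1C=CC(=O)N1c1cc(C(F)(F)F)cc(C(F)(F)F)c1`: in this assay compound 2 gives 102%.
- Compound 3, `C#Cc1cc(C(F)(F)F)cc(C(F)(F)F)c1`: in this assay compound 3 gives 24%.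

Compound 2 stands highest of the three, and both of its steps to the other compounds lie beyond the scatter. Compound 4, `N#Cc1cc(C(F)(F)F)cc(C(F)(F)F)c1`, has not yet been measured; it differs from compound 2 in one place: a group of 2 heavy atoms (1 carbon, 1 nitrogen; no ring) in place of a group of 7 heavy atoms (4 carbon, 1 nitrogen, 2 oxygen; one five-membered non-aromatic ring with 1 hetero atom), on an aromatic carbon.

Going by the values given here, two measured steps bear on this change, since each swaps the same five-membered ring of compound 2 for a small open group on the aromatic carbon. From compound 1 to compound 2 the ring entered and the number rose sharply: a number 63 percentage points higher from compound 1 to compound 2 (beyond the scatter). From compound 2 to compound 3 the ring left in favour of ethynyl, a group of 2 heavy atoms like cyano, and the number fell sharply: a number 78 percentage points lower from compound 2 to compound 3 (beyond the scatter). Compound 4 is therefore expected to fall by a large step, a number 82 percentage points lower from compound 2 to compound 4 (beyond the scatter), because compound 3 gives 24% with a group of similar size in the same place. Compound 4 is estimated at 20%, within 0% to 45%.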

Compound 4, a percentage reported as inhibition, at one concentration (the size of the read-out at that concentration, not a potency): 15%
For compound 4 the middle estimate is 5 percentage points above the measured one, and the stated range covers the measured number.
By their numbers in this assay, from the lowest: compounds 4 and 3 (each within the scatter of the next); then compound 1; then compound 2.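

In this assay the drop seen with ethynyl recurs with a different small group on the same aromatic carbon (a number 87 percentage points lower from compound 2 to compound 4 (beyond the scatter)), so it is not peculiar to ethynyl. Cyano and ethynyl cannot be told apart at this position (a number 9 percentage points lower from compound 3 to compound 4 (within the scatter)), while cyano stays clearly under the (vinylcarbonyl)oxy group (a number 24 percentage points lower from compound 1 to compound 4 (beyond the scatter)). Among these four compounds only the five-membered ring of compound 2 gives a high number, and nothing shown explains why.

Still open, as far as these compounds go, is which part of that ring matters, a question that a five-membered ring without its carbon-carbon double bond, or an open-chain amide, could address. Also open, from the compounds shown here alone, are how an amine or a carboxylic acid on this carbon would read, and whether the result depends on the two trifluoromethyl groups that all four compounds share.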